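The source may report more compounds than this note shows. Statements on the series, on what has been measured and on what is new or still open speak of the compounds shown alone.

Of the compounds shown here, three have so far been measured in an assay on isolated protein for inhibition of ubiquitin carboxyl-terminal hydrolase 7 (Homo sapiens), with stated times of 30 min and 2 h; a higher number here means a weaker inhibitor, a lower number a stronger inhibitor. Compound 1 `Cn1nc2c(=O)n(CC3(O)CCN(Cc4ccc(-c5ccco5)cc4Cl)CC3)cnc2c1-c1ccc(CNCCO)cc1` gives 8.2 nM in this assay. Compound 2 `Cn1nc2c(=O)n(CC3(O)CCN(Cc4ccc(-c5n[nH]c(=O)o5)cc4Cl)CC3)cnc2c1-c1ccc(CN)cc1` gives 171 nM in this assay, and compound 3 `Cn1nc2c(=O)n(CC3(O)CCN(Cc4ccc(C5=CCCC5)cc4Cl)CC3)cnc2c1-c1ccc(CN)cc1` gives 76.9 nM in this assay. Within the data shown here, the only step between measured compounds that differ in a single place is a 2.2-fold lower number from compound 2 to compound 3 (0.35 log units; beyond the scatter). Compound 1 holds the lowest of the three numbers; compound 3 stands nearest to it and compound 2 furthest, and both of those gaps lie beyond the scatter.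

Compound 4 `CCNCc1ccc(-c2c3ncn(CC4(O)CCN(Cc5ccc(-c6ccco6)cc5Cl)CC4)c(=O)c3nn2C)cc1` has not yet been measured. It differs from compound 1 in one place: hydrogen in place of hydroxy on a saturated chain carbon, two bonds along the chain from an amine nitrogen. Read one bond further out, the (2-hydroxyethyl)amino group becomes ethylamino. Among the measured compounds shown here, no measured step bears on this part of the molecule; the single step in hand concerns a ring group elsewhere in the shared core and offers no guide. The change removes one hydrogen-bond donor and one hydrogen-bond acceptor at the end of a short chain, and in the absence of a comparable step a small move toward a higher number, at or just beyond the scatter, is expected. The step expected is a 1.6-fold higher number from compound 1 to compound 4 (0.20 log units; within the scatter). Compound 4 is therefore estimated at 13 nM, with a range from 5 nM to 35 nM.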

Compound 4, half-maximal inhibitory concentration: 15.2 nM
For compound 4 the middle estimate is 1.2-fold (0.07 log units) below the measured one, within the range that was stated.
By their numbers in this assay, from the lowest: compounds 1 and 4 (each within the scatter of the next); then compound 3; then compound 2.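

In this assay, among these compounds, the step of a 1.9-fold higher number from compound 1 to compound 4 (0.27 log units; within the scatter) gives the first reading at this end of the molecule, where the earlier compounds offered no comparison. Hydrogen in place of hydroxy, on a saturated chain carbon two bonds along the chain from an amine nitrogen, therefore leaves compound 1 and compound 4 indistinguishable in this assay, and with this shared core and furan-bearing end, the hydroxy is not shown to be required for a value of this order. No supporting measurement is available to explain this result beyond the two values themselves.

The compounds shown leave open how this chain would read with a methoxy group or a carboxylic acid at its end, or as a longer chain such as 3-hydroxypropyl, since this single pair tests only the loss of the hydroxy. Compound 2 and compound 3 carry a primary amine at this end but also differ from compound 1 and compound 4 in the ring group elsewhere, and no pair shown sets that primary amine directly against ethylamino or (2-hydroxyethyl)amino.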